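A few compounds are considered here, and "the series" means these few. Any claim that something is new, unique, unknown or untested is made for them only; others in the source may bear on it.

Measured so far in an assay on cells for inhibition of histone deacetylase 8 (Homo sapiens), read by fluorescence, with a stated time of 30 min; on this read-out lower numbers stand for stronger inhibition and higher numbers for weaker inhibition:
Compound 1 `O=C1NC(=O)/C(=C\c2ccc(OCC(=O)N3N=C(c4ccccc4)CC3c3ccccc3Cl)cc2)S1` gives 29000 nM.
Compound 2 `O=C1NC(=O)/C(=C\c2ccc(OCC(=O)N3N=C(c4ccc(F)cc4)CC3c3ccccc3Cl)cc2)S1` gives > 50000 nM, which is a limit of this assay and not a number.

Compound 2 therefore stands at the limit (the limit of > 50000 nM in this assay, at which 1 of the 2 values shown sits); it has no numeric value in this assay, only a range. Within the data shown here, the one measured step, an at least 1.7-fold higher number from compound 1 to compound 2 (0.23 log units; that floor lies within the scatter), moves from a number to that limit, and its floor lies within the scatter, so it sets no firm size.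

Compound 3 `O=C1NC(=O)/C(=C\c2ccc(OCC(=O)N3N=C(c4ccc(F)cc4)CC3c3ccc(F)cc3)cc2)S1` differs from compound 2 by 4-fluorophenyl in place of 2-chlorophenyl on a saturated ring carbon. Among the measured compounds shown here, the one measured step concerns a fluoro in place of hydrogen on an aromatic carbon, a different exchange at a different place, so it does not bear directly on this change; no measured step covers the exchange of a 2-chlorophenyl for a 4-fluorophenyl on the saturated ring carbon. With compound 2 already at the limit, the expectation is that compound 3 also returns no number beyond the scatter of that limit; the step from compound 2 to compound 3 is estimated as a step that the limit leaves unreadable from compound 2 to compound 3. Compound 3 is thus expected at 60000 nM, within 20000 nM to 200000 nM.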

Compound 3, half-maximal inhibitory concentration: > 50000 nM
Compound 3 gave a limit, no number (the forecaster's own chance of this, stated with the estimate: 70%); the middle value lies beyond the limit too.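

No step can be read between compound 2 and compound 3 in this assay, since both sit at the same limit, which is not a number: the limit of > 50000 nM in this assay, at which 2 of the 3 values shown sit. Left open is what effect, if any, the exchange of 2-chlorophenyl for 4-fluorophenyl on the saturated ring carbon has in this assay.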